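Series notes: acetyl replacing (dimethylcarbamoyl)methoxy in compound 4

The compounds below may be only part of what the source reports. "The series", "measured", "known", "first", "only" and "open" are said of these compounds alone.

The series is followed in an assay on isolated protein (strain Sprague-Dawley) for inhibition of Amine oxidase [flavin-containing] B (Rattus norvegicus), read by spectrophotometry, with a stated time of 5 min; a lower number here means a stronger inhibitor, a higher number a weaker inhibitor. Compound 1 `COc1cc(=O)oc2cc(OCc3cccc(F)c3)ccc12` gives 36.3 nM. For the measured compounds named here, compound 2 `CCCOc1cc(=O)oc2cc(OCc3cccc(F)c3)ccc12` gives 407 nM; the single measured step, an 11-fold higher number from compound 1 to compound 2 (1.05 log units; beyond the scatter), is large. Compound 3 `CN(C)C(=O)COc1cc(=O)oc2cc(OCc3cccc(Cl)c3)ccc12` gives 501 nM. Its number lies close to that of compound 2, within the usual scatter, and far from that of compound 1, beyond it.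

Compound 4 `CC(=O)c1cc(=O)oc2cc(OCc3cccc(Cl)c3)ccc12` differs from compound 3 in one place: acetyl in place of (dimethylcarbamoyl)methoxy on an aromatic carbon. Going by the values given here, no measured step shares this change. Among the compounds with values here, the one step available concerns an ethyl added on a saturated chain carbon, not the exchange of a whole group on an aromatic carbon, so it cannot be carried over directly; it only shows that the series is sensitive to changes of this general kind, and that the compound with the smallest group at that part of the core, compound 1, sits lowest. Within the data shown here, the entering acetyl has fewer heavy atoms than the leaving group, which points toward a lower number, but with no matching step the direction is uncertain.

For compound 4 a moderate step toward a lower number is expected, a 3.1-fold lower number from compound 3 to compound 4 (0.50 log units; beyond the scatter), beyond the scatter but loosely held. Compound 4 is therefore estimated at 160 nM, with a range from 30 nM to 900 nM.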

Compound 4, half-maximal inhibitory concentration: 39.8 nM
For compound 4 the middle estimate is 4.0-fold (0.60 log units) above the measured one, and the stated range covers the measured number.
By their numbers in this assay, from the lowest: compounds 1 and 4 (each within the scatter of the next); then compounds 2 and 3 (each within the scatter of the next).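

In this assay acetyl in place of (dimethylcarbamoyl)methoxy on this aromatic carbon, opposite the ring oxygen, gives a 13-fold lower number from compound 3 to compound 4 (1.10 log units; beyond the scatter) as a large step, so the number at this position responds strongly to the exchange of a whole group and not only to the chain change seen earlier in the series. The earlier compounds shown here all carry a group attached through oxygen at this carbon, whereas compound 4 carries a carbonyl group attached directly through carbon and still reaches 39.8 nM in this series. No measurement accompanies the result that would explain the size of this step.

The compounds shown do not separate the loss of (dimethylcarbamoyl)methoxy from the gain of acetyl, and it remains open whether other groups bound through carbon at this position, such as a primary amide, a carboxylic acid or a longer ketone chain, would give similar numbers. Compound 4 and the methoxy compound 1 also differ in their halogen, fluorine in compound 1 and chlorine in compound 4, so the acetyl and methoxy groups cannot be set directly against each other.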